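From methyl to trifluoromethyl on the shared core

The source may hold more compounds than are shown below. What is called first, only, known or untested is meant among the compounds shown, and "the series" means these compounds.

In an in vivo ADME assay on the whole organism for pharmacokinetics, with Canis familiaris (Canis lupus familiaris) as the target (a higher number here means faster removal of the compound, a lower number slower removal), compound 1 `Nc1noc2ccc(-n3nc(C(F)(F)F)c4c3C(=O)N(c3ccc(-c5ccccc5CN5CCCC5)cc3F)CC4)cc12` gives 13.2 mL/min/kg, while compound 2 `Cc1nn(-c2ccc3onc(N)c3c2)c2c1CCN(c1ccc(-c3ccccc3CN3CCCC3)cc1)C2=O` gives 31.7 mL/min/kg, the higher of the two numbers and a gap beyond the scatter. Compound 3 `Nc1noc2ccc(-n3nc(C(F)(F)F)c4c3C(=O)N(c3ccc(-c5ccccc5CN5CCCC5)cc3)CC4)cc12` departs from compound 2 at one place: trifluoromethyl in place of methyl on an aromatic carbon. Among the compounds with values here, no measured pair isolates this change. The trifluoromethyl is shared with compound 1 at 13.2 mL/min/kg, although compound 1 also differs from compound 3 elsewhere. In this assay a fall is therefore expected, an estimated 2.1-fold lower number from compound 2 to compound 3 (0.32 log units; beyond the scatter). For compound 3 the expected clearance is 15 mL/min/kg, within an estimated range of 7 mL/min/kg to 30 mL/min/kg.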

Compound 3, clearance: 16.8 mL/min/kg
For compound 3 the middle estimate is 1.1-fold (0.05 log units) below the measured one; low and high end bracket the measured number.
By their numbers in this assay, from the lowest: compounds 1, 3 and 2 (each within the scatter of the next, the first and the last beyond it).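

In this assay the change from methyl to trifluoromethyl on the aromatic carbon now has its own measured pair, which gives a 1.9-fold lower number from compound 2 to compound 3 (0.28 log units; within the scatter) and so does not separate this change from the scatter. The fluoro present in compound 1 is also isolated, and hydrogen in its place gives a 1.3-fold higher number from compound 1 to compound 3 (0.10 log units; within the scatter) on otherwise the same structure. Nothing given here accounts for either step. The compounds shown leave open how a chloro, an ethyl or a nitrile on this aromatic carbon would read in this assay and whether methyl behaves the same alongside the fluoro.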